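The source may hold more compounds than are shown below. What is called first, only, known or untested is meant among the compounds shown, and "the series" means these compounds.

Of the compounds shown here, two have so far been tested in an assay for inhibition of Amine oxidase [flavin-containing] A (Bos taurus), read by fluorescence, with a stated time of 60 min; on this read-out higher numbers stand for weaker inhibition and lower numbers for stronger inhibition. Compound 1 `COc1ccc(C(=O)NNc2nc3ccccc3nc2Cc2ccccc2)cc1` gives 86 nM, and compound 2 `Cc1ccc(C(=O)NNC(=O)Cn2c(=O)c(Cc3ccccc3)nc3ccccc32)cc1` gives 52 nM. Compound 2 holds the lower of these two numbers, yet compound 1 sits within the scatter of it, so the pair cannot be separated. Compound 3 `C/C(=N\NC(=O)Cn1c(=O)c(Cc2ccccc2)nc2ccccc21)c1ccc(O)cc1` is compound 2 with one change: a group of 10 heavy atoms (8 carbon, 1 nitrogen, 1 oxygen; one six-membered aromatic ring of carbon only) in place of a group of 10 heavy atoms (8 carbon, 1 nitrogen, 1 oxygen; one six-membered aromatic ring of carbon only), on an amide-type nitrogen. Within the data shown here, no measured pair shows what such a swap does here, so the step from compound 2 to compound 3 is expected to be small, a 1.3-fold higher number from compound 2 to compound 3 (0.10 log units; within the scatter), not beyond the scatter. Compound 3 is therefore expected to give about 65 nM in this assay, somewhere between 20 nM and 220 nM.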

Compound 3, half-maximal inhibitory concentration: 1.6 nM
Beside the measured number, compound 3's estimate is 41-fold (1.61 log units) above it; the whole stated range lies above it.
By their numbers in this assay, from the lowest: compound 3; then compounds 2 and 1 (each within the scatter of the next).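

The group on the amide-type nitrogen turns out to matter greatly in this assay: exchanging ((4-methylphenyl)carbonyl)amino for a group with the same heavy atoms gives a 33-fold lower number from compound 2 to compound 3 (1.51 log units; beyond the scatter), which means much stronger inhibition. So matching atom counts did not make these two groups interchangeable at this position. Nothing measured here says why. From the compounds shown here alone, the exchange alters the group in several ways at once, so it remains open which part of it matters. Going by these compounds, it is also open whether an amine or a methoxy group in place of the hydroxyl on the ring of compound 3 would keep this strength.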